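Adding a Methoxy to the Ketone-Side Ring of Compound 2

This account rests on a few compounds, and the source may have more. Where it says the series, first, only, none or still open, it means among the compounds named here.

Measured compounds:
- Compound 1, `COc1cc(-c2cc(/C=C/C(=O)c3ccc(N)cc3)[nH]n2)cc(OC)c1OC`: 4710 nM
- Compound 2, `COc1ccc(C(=O)/C=C/c2cc(-c3cc(OC)c(OC)c(OC)c3)n[nH]2)cc1OC`: 3680 nM

Compound 1 was tested in a functional assay on Malme-3M cells (Homo sapiens) for inhibition, read by sulforhodamine B assay, with a stated time of 48 h (a lower number here means a stronger inhibitor of growth, a higher number a weaker inhibitor of growth), where compound 1 gives 4710 nM. In compound 2 a 3,4-dimethoxyphenyl stands on the carbonyl carbon in place of the 4-aminophenyl of compound 1. In this assay compound 2 gives 3680 nM. This is the lower of the two numbers, but the step of a 1.3-fold lower number from compound 1 to compound 2 (0.11 log units; within the scatter) is too small to set the two apart.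

Compound 3, `COc1cc(C(=O)/C=C/c2cc(-c3cc(OC)c(OC)c(OC)c3)n[nH]2)cc(OC)c1OC`, carries the change methoxy in place of hydrogen on an aromatic carbon on the ring attached to the carbonyl carbon of compound 2, so that ring now carries three methoxy groups. Among the measured compounds shown here, no measured pair shows what a further methoxy on this ring does; the only step at hand, a 1.3-fold lower number from compound 1 to compound 2 (0.11 log units; within the scatter), concerns a change of the whole ring and stayed within the scatter. For the measured compounds named here, nothing among the measured compounds therefore points to a step beyond the scatter, and compound 3 is expected to give about 3500 nM in this assay, with a range from 1200 nM to 10000 nM, so that the expected step of a 1.1-fold lower number from compound 2 to compound 3 (0.02 log units; within the scatter) is small.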

Compound 3, concentration for total growth inhibition: 4090 nM
Beside the measured number, compound 3's estimate is 1.2-fold (0.07 log units) below it, and the stated range covers the measured number.
By their numbers in this assay, from the lowest: compounds 2, 3 and 1 (each within the scatter of the next).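

In this assay, among the compounds shown here, the step of a 1.1-fold higher number from compound 2 to compound 3 (0.05 log units; within the scatter) gives the first direct reading at this position: methoxy in place of hydrogen, on the aromatic carbon ortho to a methoxy group and meta to a large group, leaves the number within the scatter. The earlier step of a 1.3-fold lower number from compound 1 to compound 2 (0.11 log units; within the scatter) exchanged the substituents of the whole ring on the carbonyl carbon, so it could not show what one added group does there, whereas the new step shows that this ring can carry a third methoxy group with no difference that this assay can resolve. Nothing independent of these growth-inhibition numbers is available to explain this result.

Going by these compounds, it remains open whether a different group at this position, such as a hydroxyl group, a chlorine atom or a carboxylic acid, would move the number beyond the scatter. On these data alone, it is equally open whether a change elsewhere on the shared core, such as a longer chain in place of one of the methoxy groups, would do so.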